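This account rests on a few compounds, and the source may have more. Where it says the series, first, only, none or still open, it means among the compounds named here.

Measured compounds:
compound 1 `CCCCc1cn(C[C@H](O)[C@H]2OC(=O)C(OCc3ccccc3)=C2OCc2ccccc2)nn1`: 18100 nM
compound 2 `O=C1O/C(=C\Cn2cc(-c3cc(C(F)(F)F)cc(C(F)(F)F)c3)nn2)C(OCc2ccccc2)=C1OCc1ccccc1`: > 100000 nM

In a functional assay on HeLa cells (Homo sapiens) for antiproliferative activity, read by MTT assay, with a stated time of 72 h (a higher number here means a weaker inhibitor, a lower number a stronger inhibitor), compound 1 gives 18100 nM. Compound 2, in this assay, reports only a limit, > 100000 nM. Compound 1 therefore holds the only number shown in this assay; the other value shown is the limit of > 100000 nM in this assay, at which 1 of the 2 values shown sits.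

Compound 3 `Cc1ccc(-c2cn(C[C@H](O)[C@H]3OC(=O)C(OCc4ccccc4)=C3OCc3ccccc3)nn2)cc1` has not yet been measured in this assay. It differs from compound 1 in one place: 4-methylphenyl in place of butyl on an aromatic carbon. For the measured compounds named here, no pair of measured compounds that differ in a single place is at hand, so the size of this step can only be expected, not read off. Compound 3 brings an aromatic ring where compound 1 carries a chain, and compound 2, which also carries an aromatic ring in that place though joined by a different linker, reaches only a limit. The step from compound 1 to compound 3 is expected to be a 1.5-fold higher number from compound 1 to compound 3 (0.19 log units; within the scatter), a modest weakening that may not clear the scatter. Compound 3 is accordingly estimated at 28000 nM, within a range from 7000 nM to 100000 nM.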

Compound 3, half-maximal inhibitory concentration: 25500 nM
The estimate for compound 3 lay 1.1-fold (0.04 log units) above the measured number, within the range that was stated.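

In this assay, replacing butyl with 4-methylphenyl on an aromatic carbon of the five-membered aromatic ring with 3 nitrogen gives a 1.4-fold higher number from compound 1 to compound 3 (0.15 log units; within the scatter), and compounds 1 and 3 cannot be told apart at this level of precision. For the compounds shown here, this is the first reading at this position: within this one pair, an open chain and a six-membered aromatic ring of carbon only give numbers that lie within the scatter of each other, even though the entering group is the larger of the two. Nothing shown here accounts for how small this step is.

The compounds shown leave open whether an amine or a carboxylic acid at this place, a chain longer than butyl, or a phenyl ring without its methyl group would give a step beyond the scatter. Going by these compounds alone, compound 2 differs from compound 1 and compound 3 in more than one place and its value is a limit, and no step to it can be read.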